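Cytotoxicity notes: from compound 2 to compound 3

The source may hold more compounds than are shown below. What is called first, only, known or untested is meant among the compounds shown, and "the series" means these compounds.

Measured in a functional assay on HCT-116 cells (Homo sapiens) for cytotoxicity, read by MTT assay, with a stated time of 72 h; on this read-out higher numbers stand for weaker inhibition and lower numbers for stronger inhibition (values below)
- Compound 1 `N[C@H]1CC[C@H](Nc2c(C(=O)NCc3ccc(F)cc3)nc(N3CCCCS3(=O)=O)c3cccnc23)CC1` gives > 10000 nM (a limit of the assay)
- Compound 2 `Nc1ccc(Nc2c(C(=O)NCc3ccc(F)cc3)nc(Br)c3cccnc23)cc1` gives 7000 nM

Going by the values given here, compound 2 holds the only actual number, and its inhibition is weak (compound 2 at 7000 nM). Compound 3 `O=C(NCc1ccc(F)cc1)c1nc(Br)c2cccnc2c1N1CCNCC1` carries piperazin-1-yl in place of (4-aminophenyl)amino on an aromatic carbon. Among the compounds with values here, no measured pair isolates this change. A small shift toward weaker inhibition is expected (a 1.3-fold higher number from compound 2 to compound 3 (0.11 log units; within the scatter)), and a result at the assay limit would not be surprising. For compound 3 the estimated value is 9000 nM (expected range 3000 nM to 30000 nM).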

Compound 3, half-maximal inhibitory concentration: > 10000 nM
Compound 3: no number, only a limit; the forecaster's own chance of this, stated with the estimate: 40%; middle value at least 1.1-fold (0.04 log units) from the limit.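

Going by these compounds alone, this is the first single-place comparison in this assay at the aromatic carbon para to a bromo group: piperazin-1-yl in place of (4-aminophenyl)amino gives an at least 1.4-fold higher number from compound 2 to compound 3 (0.15 log units; that floor lies within the scatter). On these data alone, compound 3 gives > 10000 nM, which is a limit of the assay, so the size of the step stays unknown and the change shows no gain in inhibition. The reading is bounded at the top: the limit of > 10000 nM in this assay, at which 2 of the 3 values shown sit.

Still open, as far as these compounds go, is whether the value of compound 2 depends on its terminal amino group or on its aromatic ring. A plain phenylamino group or a cyclohexylamino group at this carbon would separate the two.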